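From methoxy to piperazin-1-yl: what compound 4 may show

This account rests on a few compounds, and the source may have more. Where it says the series, first, only, none or still open, it means among the compounds named here.

Measured in an ADME assay on MCF7-DOX cells (Homo sapiens) for cytotoxicity, read by MTT assay, with a stated time of 48 h (a lower number here means a stronger inhibitor, a higher number a weaker inhibitor), so far:
Compound 1 `COc1cc(O)c(C(=O)/C=C/c2ccc(N3CCNCC3)cc2)c(OC)c1` gives 67500 nM
Compound 2 `COc1cc(OC)c(C(=O)/C=C/c2ccc(C(F)(F)F)cc2)c(O)c1CC=C(C)C` gives 73700 nM
Compound 3 `COc1ccc(/C=C/C(=O)c2c(OC)cc(OC)c(CC=C(C)C)c2O)cc1` gives 46900 nM

The number for compound 3 lies within the scatter of those for both compound 1 and compound 2, so it holds no clear rank among them. Compound 4 `COc1cc(OC)c(C(=O)/C=C/c2ccc(N3CCNCC3)cc2)c(O)c1CC=C(C)C` has piperazin-1-yl in place of methoxy on an aromatic carbon of compound 3, a change counted as piperazin-1-yl in place of methoxy on an aromatic carbon in full.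

Among the measured compounds shown here, only one measured step touches this place, and it involves a different swap, methoxy in place of trifluoromethyl. That step, a 1.6-fold lower number from compound 2 to compound 3 (0.20 log units; within the scatter) in this assay and thus inside the scatter, gives no reason to expect a clear shift. Compound 1 carries piperazin-1-yl on a different core, and its 67500 nM lies within the scatter of compound 3. For the measured compounds named here, no measured pair shows this exact swap, so the range must stay wide, and no direction can be claimed. The estimated change is a 1.1-fold lower number from compound 3 to compound 4 (0.05 log units; within the scatter) and is expected to stay within the scatter. Compound 4 is expected to give 42000 nM with 16000 nM to 85000 nM as the estimated range.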

Compound 4, half-maximal inhibitory concentration: 57800 nM
The estimate for compound 4 lay 1.4-fold (0.14 log units) below the measured number; the measured number falls inside the stated range.
By their numbers in this assay, from the lowest: compounds 3, 4, 1 and 2 (each within the scatter of the next).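

In this assay, the swap from methoxy to piperazin-1-yl on the shared core can now be read directly: a 1.2-fold higher number from compound 3 to compound 4 (0.09 log units; within the scatter), so placing this larger group with its six-membered non-aromatic ring on the aromatic carbon leaves no clear mark on the number. The comparison with trifluoromethyl at the same place gives the same picture, with a 1.3-fold lower number from compound 2 to compound 4 (0.11 log units; within the scatter), so methoxy, trifluoromethyl and piperazin-1-yl cannot be told apart here. The second place also gains its first reading, as adding 3-methylbut-2-en-1-yl in place of hydrogen gives a 1.2-fold lower number from compound 1 to compound 4 (0.07 log units; within the scatter), again no clear shift.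

From the compounds shown here alone, whether a carboxylic acid, a simple primary amine or a longer carbon chain at the first place would move the number beyond the scatter remains open. Nothing shown here offers an explanation for how close these numbers lie.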